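Replacing 3-Hydroxyphenyl with tert-Butyl on the Shared Core

The compounds below may be only part of what the source reports. "The series", "measured", "known", "first", "only" and "open" are said of these compounds alone.

Measured compounds:
- compound 1 `O=C1O[C@H]([C@@H](O)Cn2cc(-c3cccc(O)c3)nn2)C(OCc2ccccc2)=C1OCc1ccccc1`: 62700 nM
- compound 2 `CCCCCc1ccc(-c2cn(C/C=C3\OC(=O)C(OCc4ccccc4)=C3OCc3ccccc3)nn2)cc1`: > 100000 nM

Of the compounds shown here, two have so far been tested in a functional assay on HepG2 cells (Homo sapiens) for antiproliferative activity, read by MTT assay, with a stated time of 72 h; a lower number here means a stronger inhibitor, a higher number a weaker inhibitor. Compound 1 gives 62700 nM in this assay, and it is the only one of the two for which a number rather than a limit is available. For compound 2 the result is a limit of the assay, > 100000 nM. That corresponds to the limit of > 100000 nM in this assay, at which 1 of the 2 values shown sits. Among the measured compounds shown here, no step between measured compounds that differ in a single place is available, so the pair shows only that compound 1 yields a number and compound 2 does not.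

Compound 3 `CC(C)(C)c1cn(C[C@H](O)[C@H]2OC(=O)C(OCc3ccccc3)=C2OCc2ccccc2)nn1` is not yet measured. Relative to compound 1 the change is tert-butyl in place of 3-hydroxyphenyl on an aromatic carbon. Without a measured comparison of the same kind, the size of the step is open; the weak number of compound 1 in this assay suggests little room for improvement and a real chance that only a limit is returned. Compound 3 is therefore expected to show a 1.3-fold higher number from compound 1 to compound 3 (0.11 log units; within the scatter). The estimated value of compound 3 in this assay is 80000 nM, within a range of 30000 nM to 200000 nM.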

Compound 3, half-maximal inhibitory concentration: 29200 nM
Beside the measured number, compound 3's estimate is 2.7-fold (0.44 log units) above it, and the stated range ends above it.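

In this assay, among the compounds shown here, tert-butyl in place of 3-hydroxyphenyl on the aromatic carbon of the five-membered aromatic ring with 3 nitrogen gives a 2.1-fold lower number from compound 1 to compound 3 (0.33 log units; beyond the scatter), the only step so far between measured compounds that differ in one place. It shows that this position does not need the six-membered aromatic ring or its hydroxyl group for a measurable result: a group with no ring, 0 hydrogen-bond donors and 0 hydrogen-bond acceptors gives a modestly lower number, although compound 3 at 29200 nM remains a weak inhibitor. Nothing at hand gives a measured reason for this step.

The compounds shown leave open whether the step goes with the loss of the aromatic ring or the loss of the hydroxyl group, as both leave in the one change. A plain phenyl group at this position would separate the two, while a cyclohexyl group or a primary amine on a short chain would show how far this position accepts other kinds of group.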